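The source may hold more compounds than are shown below. What is called first, only, known or untested is meant among the compounds shown, and "the series" means these compounds.

Working notes on the shared core in a functional assay on A549 cells (Homo sapiens) for inhibition, read by MTT assay, with a stated time of 24 h; a lower number here means a stronger inhibitor, a higher number a weaker inhibitor: compound 1 (`CC1(C)[C@H]2CC[C@]1(C)N(Cc1cn(-c3ccccc3F)nn1)C(=O)C2`) gives 240 nM, compound 2 (`CC1(C)[C@H]2CC[C@]1(C)N(Cc1cn(-c3ccc(Br)cc3)nn1)C(=O)C2`) gives 80 nM and compound 3 (`Cc1ccc(-n2cc(CN3C(=O)C[C@@H]4CC[C@@]3(C)C4(C)C)nn2)cc1`) gives 400 nM. Two steps place the last of these: there is a 1.7-fold higher number from compound 1 to compound 3 (0.22 log units; within the scatter), and there is a 5.0-fold higher number from compound 2 to compound 3 (0.70 log units; beyond the scatter). Its number therefore sits with that of compound 1, while the number of compound 2 stands apart on the low side.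

The next change leads to compound 4 (`CC1(C)[C@H]2CC[C@]1(C)N(Cc1cn(-c3cccc(Br)c3)nn1)C(=O)C2`), with 3-bromophenyl in place of 4-methylphenyl on an aromatic nitrogen. The closest evidence is the bromo and methyl pair, where compound 2 at 80 nM lies lower, and a 3.0-fold lower number from compound 1 to compound 2 (0.48 log units; beyond the scatter) also favours the 4-bromophenyl group. Both steps are modest, and both rest on a single bromo compound. Going by the values given here, no measured compound carries 3-bromophenyl, so only part of that gain is carried over, and a modest move to a lower number is expected.

The estimated step is a 2.9-fold lower number from compound 3 to compound 4 (0.46 log units; beyond the scatter). The expected value for compound 4 is 140 nM, with an estimated range of 50 nM to 380 nM.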

Compound 4, half-maximal inhibitory concentration: 90 nM
Beside the measured number, compound 4's estimate is 1.6-fold (0.19 log units) above it; measured number inside the range.
By their numbers in this assay, from the lowest: compounds 2 and 4 (each within the scatter of the next); then compounds 1 and 3 (each within the scatter of the next).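

In this assay, the two bromophenyl compounds do not separate, with a 1.1-fold higher number from compound 2 to compound 4 (0.05 log units; within the scatter), so moving the bromo group from the 4-position to the 3-position of the phenyl ring shows no readable change. The advantage of bromophenyl over the other aryl groups now rests on two compounds rather than one, with a 4.4-fold lower number from compound 3 to compound 4 (0.65 log units; beyond the scatter) and a 2.7-fold lower number from compound 1 to compound 4 (0.43 log units; beyond the scatter). No measurement at hand offers an explanation for this advantage.

Still open is whether the advantage belongs to bromine itself or would also appear with 3-chlorophenyl or 4-chlorophenyl, as the only other halogen shown is the fluoro group of 2-fluorophenyl. Also open, from the compounds shown here alone, is how this position would respond to a phenyl ring carrying an amine or a carboxylic acid.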